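This account rests on a few compounds, and the source may have more. Where it says the series, first, only, none or still open, it means among the compounds named here.

Compound 1, `O=C(CCC1=CCN(CCCc2ccc(Br)cc2)C1=O)NO`, gives 2210 nM in a functional assay on MDA-MB-231 cells (Homo sapiens) for inhibition, read by sulforhodamine B assay; on this read-out lower numbers stand for stronger inhibition of growth and higher numbers for weaker inhibition of growth.
Compound 2, `O=C(CCC1=CCN(CCCc2ccc(Cl)cc2)C1=O)NO`, gives 2210 nM in this assay.
Compound 3, `O=C(CCC1=CCN(Cc2cccc(Br)c2)C1=O)NO`, gives 1990 nM in this assay.

The three measured compounds sit close together. Compound 1 and compound 2 share one core and differ by chloro in place of bromo on an aromatic carbon; this change gave no change at the digits printed from compound 1 to compound 2 (within the scatter). Compound 3 carries a different core, and the difference between the two cores is not broken down here; its value and that of compound 1 lie within the scatter of each other, as do its value and that of compound 2.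

Compound 4, `O=C(CCC1=CCN(Cc2cccc(Cl)c2)C1=O)NO`, has not yet been measured. It differs from compound 3 by chloro in place of bromo on an aromatic carbon. This is the same kind of change as that from compound 1 to compound 2, with the place differing in its surroundings: in compound 4 the chloro stands meta to a large group, whereas in compound 2 it stands para to a large group. Because no change at the digits printed from compound 1 to compound 2 (within the scatter) was flat, compound 4 is expected to show a 1.0-fold higher number from compound 3 to compound 4 (0.00 log units; within the scatter), a step of about the same size. For compound 4 the estimated value in this assay is 2000 nM, with a range from 1100 nM to 3600 nM.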

Compound 4, concentration for 50% growth inhibition: 1990 nM
Estimate against measurement, compound 4: 1.0-fold (0.00 log units) above; the range from low to high includes it.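

In this assay, chloro in place of bromo on an aromatic carbon, here meta to a large group, gave no change at the digits printed from compound 3 to compound 4 (within the scatter). Set beside the earlier step, the exchange carries over from one core to the other without a detectable difference: the same change on two cores in this assay, no change at the digits printed (within the scatter) from compound 1 to compound 2 and no change at the digits printed (within the scatter) from compound 3 to compound 4, 1.0-fold (0.00 log units) apart, within the scatter of two such steps This shows only that the exchange of these two halogens was flat on these two cores, and it neither explains that flatness nor shows that the same would hold on a further core, since the two cores also differ in the chain and in where the halogen sits on the ring.

The compounds shown leave open whether a ring substituent other than bromo or chloro, such as fluoro, methoxy, trifluoromethyl or an amine, would give a step beyond the scatter on either core. They also leave open what a carboxylic acid would give in place of the hydroxamic acid, and how a longer chain would compare on the same ring.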